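The source may hold more compounds than are shown below. What is called first, only, known or untested is meant among the compounds shown, and "the series" means these compounds.

Series notes on the shared core, read in an ADME assay on HEK-293T cells (Homo sapiens) for cytotoxicity, read by MTT assay, with a stated time of 24 h; on this read-out lower numbers stand for stronger inhibition and higher numbers for weaker inhibition.

Compound 1 `O=Cc1ccccc1OCc1cn(CCCOc2ccc3ccc(=O)oc3c2)nn1` carries a formyl group on the phenoxy ring and gives 13700 nM in this assay. Compound 2 `O=Cc1cc(Br)ccc1OCc1cn(CCCOc2ccc3ccc(=O)oc3c2)nn1` differs from compound 1 by bromo in place of hydrogen on an aromatic carbon, (bromo in place of hydrogen on an aromatic carbon). In this assay compound 2 gives 6080 nM; the step reads a 2.3-fold lower number from compound 1 to compound 2 (0.35 log units; beyond the scatter). Compound 3 `NS(=O)(=O)c1ccc(C/N=C/c2ccccc2OCc2cn(CCCOc3ccc4ccc(=O)oc4c3)nn2)cc1` replaces the formyl group of compound 1 with a sulfonamide-bearing imine arm. In this assay compound 3 gives 13900 nM; the difference between the cores of compound 1 and compound 3 is not broken down here, and their two values sit within the usual scatter of one another. Compound 4 `NS(=O)(=O)c1ccc(C/N=C/c2cc(Br)ccc2OCc2cn(CCCOc3ccc4ccc(=O)oc4c3)nn2)cc1` is not yet measured in this assay; it differs from compound 3 by bromo in place of hydrogen on an aromatic carbon. The change is the same kind as that from compound 1 to compound 2, though the surroundings differ: in compound 2 the bromo stands meta to a formyl group (2 heavy atoms) and para to a large group, whereas in compound 4 it stands meta to a large group and para to a large group. The measured bromo step reads a 2.3-fold lower number from compound 1 to compound 2 (0.35 log units; beyond the scatter), and it rests on the fact that compound 1 gives 13700 nM while compound 2 gives 6080 nM. A step of a similar size in this assay is expected from compound 3 to compound 4, namely a 2.2-fold lower number from compound 3 to compound 4 (0.35 log units; beyond the scatter). Compound 4 is thus estimated at 6200 nM, with a plausible range from 3500 nM to 14000 nM.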

Compound 4, half-maximal inhibitory concentration: 8250 nM
The estimate for compound 4 lay 1.3-fold (0.12 log units) below the measured number, within the range that was stated.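

In this assay, bromo in place of hydrogen on an aromatic carbon, here meta to a large group and para to a large group, gives a 1.7-fold lower number from compound 3 to compound 4 (0.23 log units; within the scatter), so on this core the step taken alone cannot be told apart from repeat measurement. Set beside the earlier step, it points the same way and does not differ from it, so as far as these two pairs go, the change carries from the formyl core to the core with the sulfonamide-bearing imine arm without a detectable shift in size: the same change on two cores in this assay, a 2.3-fold lower number (0.35 log units; beyond the scatter) from compound 1 to compound 2 and a 1.7-fold lower number (0.23 log units; within the scatter) from compound 3 to compound 4, 1.3-fold (0.13 log units) apart, within the scatter of two such steps. Among the compounds shown here, this does not show that bromo reliably lowers the number on the imine core, since only the step on the formyl core lies beyond the scatter, and two pairs give no rule for other cores or any reason for the size of the step.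

Open, on these data alone, is whether chloro or methoxy in place of bromo would give a step of similar size on both cores. Also open, as far as these compounds go, is whether the bromo step would hold with a carboxylic acid in place of the sulfonamide, or with a longer chain in the linker of the shared core.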